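Removing a Chloro Group from a Chalcone Ether

The source may report more compounds than this note shows. Statements on the series, on what has been measured and on what is new or still open speak of the compounds shown alone.

Measured so far:
compound 1, `CNC(=O)c1cc(Oc2ccc(C(=O)/C=C/c3ccc(F)cc3Cl)cc2)ccn1`: 21100 nM
compound 2, `CNC(=O)c1cc(Oc2ccc(/C=C/C(=O)c3ccc(C)cc3)cc2)ccn1`: 24900 nM

Both compounds were tested in a functional assay on MCF7 cells (Homo sapiens) for cytotoxicity, read by MTT assay, with a stated time of 72 h; on this read-out lower numbers stand for stronger inhibition and higher numbers for weaker inhibition. Compound 1, `CNC(=O)c1cc(Oc2ccc(C(=O)/C=C/c3ccc(F)cc3Cl)cc2)ccn1`, gives 21100 nM. Compound 2, `CNC(=O)c1cc(Oc2ccc(/C=C/C(=O)c3ccc(C)cc3)cc2)ccn1`, gives 24900 nM. Where compound 1 stands is simple to say: its number and that of compound 2 lie within the usual scatter of each other, so the two cannot be told apart on these data, and neither can be called the more active one.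

Compound 3, `CNC(=O)c1cc(Oc2ccc(C(=O)/C=C/c3ccc(F)cc3)cc2)ccn1`, has not been measured. It differs from compound 1 in a single place: hydrogen in place of chloro on an aromatic carbon. Going by the values given here, no measured pair here shares this kind of change, so there is no step to lean on; the expectation rests only on how modest the change is and on how close the two measured numbers already are.

On that basis the step from compound 1 to compound 3 is expected to stay within the scatter, a 1.2-fold higher number from compound 1 to compound 3 (0.07 log units; within the scatter), with no clear direction. Compound 3 is therefore expected to give about 25000 nM in this assay, somewhere between 10000 nM and 60000 nM.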

Compound 3, half-maximal inhibitory concentration: 28500 nM
Compound 3: middle estimate off by 1.1-fold (0.06 log units), on the low side; low and high end bracket the measured number.
By their numbers in this assay, from the lowest: compounds 1, 2 and 3 (each within the scatter of the next).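

In this assay, going from the 2-chloro-4-fluorophenyl group to the 4-fluorophenyl group gives a 1.4-fold higher number from compound 1 to compound 3 (0.13 log units; within the scatter), so on these data this single change has no effect that can be told apart from the ordinary variation between repeated measurements. Compound 1 and compound 2 differ in more than one place, so they could not show what happens at this one position, ortho to a large group and meta to a fluoro group. Here the chloro group can be replaced by hydrogen with no detectable difference in the number, though no measurement shown here offers any explanation for this result.

On these data alone, only chloro and hydrogen are compared at this position, so it remains open whether another group there, such as an amine, a methoxy group or a carboxylic acid, would move the number beyond the scatter. Also open, as far as these compounds go, is what would happen if the fluoro group were replaced, since compound 1 and compound 3 both carry it.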